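A Carbonyl Step from the Assay Limit

This account rests on a few compounds, and the source may have more. Where it says the series, first, only, none or still open, it means among the compounds named here.

Of the compounds shown here, two built on related sulfonamide-linked scaffolds have been tested so far, compound 1 `Cc1cccc(NNC(=O)c2ccc(NS(=O)(=O)c3cnc(O)nc3O)cc2)c1` and compound 2 `Cc1ccccc1NNC(=O)c1ccccc1NS(=O)(=O)c1cnc(O)nc1O`. In a functional assay on OVCAR-3 cells (Homo sapiens) for antiproliferative activity, read by MTT assay, with a stated time of 24 h (a lower number here means a stronger inhibitor, a higher number a weaker inhibitor), compound 1 gives > 20000 nM, which is a limit of the assay and not a number. Compound 2 gives > 20000 nM in this assay, and this too is a limit. Compound 2 therefore has no exact position in the series, and the whole measured set stands at one reading: the limit of > 20000 nM in this assay, at which 2 of the 2 values shown sit.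

The next compound, compound 3 `Cc1ccccc1C(=O)NNC(=O)c1ccccc1NS(=O)(=O)c1cnc(O)nc1O`, carries (2-methylphenyl)carbonyl in place of 2-methylphenyl on an amine nitrogen. Going by the values given here, no measured pair shows what size of step such a change brings. Among the compounds with values here, the only anchor is compound 2 at > 20000 nM, a limit. A small shift toward a stronger inhibitor is therefore expected at most, and the reading may well remain at the limit. The expected change is a number no higher from compound 2 to compound 3 (the limit leaves the size open) in this assay. For compound 3 the estimated value is 20000 nM, with an expected range of 8000 nM to 40000 nM.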

Compound 3, half-maximal inhibitory concentration: > 20000 nM
Compound 3: a limit, no number; the forecaster's own chance of this, stated with the estimate: 60%; the middle value sits exactly at the limit.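

Compound 3, like compound 2, stands at a limit of the assay and not at a number, so no step can be read between compound 2 and compound 3. The compounds shown leave open how the added carbonyl would act on a measurable reading, and the whole set rests at one point: the limit of > 20000 nM in this assay, at which 3 of the 3 values shown sit.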